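A few compounds are considered here, and "the series" means these few. Any claim that something is new, unique, unknown or untested is made for them only; others in the source may bear on it.

Compound 1 `COc1cc(C(=O)c2ccc3[nH]ccc3c2)cc(OC)c1OC`: 88 nM
Compound 2 `CCCn1ccc2cc(C(=O)c3cc(OC)c(OC)c(OC)c3)ccc21`: 680 nM

Both values come from a functional assay on MKN-45 cells (Homo sapiens) for inhibition, with a stated time of 72 h; on this read-out higher numbers stand for weaker inhibition and lower numbers for stronger inhibition. Compound 2, at 680 nM, has the higher of the two numbers, which makes it the weaker inhibitor of the pair. For the measured compounds named here, the only measured step is a 7.7-fold higher number from compound 1 to compound 2 (0.89 log units; beyond the scatter), where propyl takes the place of hydrogen on an aromatic nitrogen.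

Compound 3 `COc1cc(C(=O)c2ccc3c(ccn3C(C)C)c2)cc(OC)c1OC` has not yet been measured. It has the same atoms as compound 2, joined differently: isopropyl in place of propyl on an aromatic nitrogen. The change falls on the same aromatic nitrogen as the measured step, so that step is the only one that bears on it. It is a weak guide, though, since it puts a group where there was only hydrogen, whereas here propyl simply gives way to isopropyl. Going by the values given here, no measured pair shows what such a swap does. The expected change in this assay is therefore small, with no firm direction: a 1.1-fold lower number from compound 2 to compound 3 (0.05 log units; within the scatter). For compound 3 the estimated value is 600 nM, with an expected range from 200 nM to 1800 nM.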

Compound 3, half-maximal inhibitory concentration: 470 nM
Compound 3: the middle estimate sits 1.3-fold (0.11 log units) above what was measured; low and high end bracket the measured number.
By their numbers in this assay, from the lowest: compound 1; then compounds 3 and 2 (each within the scatter of the next).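

In this assay, a straight propyl and a branched isopropyl on the aromatic nitrogen cannot be told apart: the result is a 1.4-fold lower number from compound 2 to compound 3 (0.16 log units; within the scatter), so joining the same three carbons differently gives no change that can be read beyond ordinary repeat variation. Branching also does not bring back the inhibition seen with hydrogen at this place, as the comparison gives a 5.3-fold higher number from compound 1 to compound 3 (0.73 log units; beyond the scatter), so both groups tested here stand beyond the scatter on the weaker side of compound 1, the strongest inhibitor of the three. Nothing available here explains why either group on this nitrogen goes with weaker inhibition, or why the two chains give numbers so close together.

The compounds shown do not tell whether a smaller group such as methyl would lie closer to compound 1, or whether a longer chain such as butyl would weaken inhibition further. They also leave open how a chain ending in an amine or a carboxylic acid would behave on the same nitrogen, since the groups seen so far are all plain carbon chains.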